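Methoxy added to the pendant phenyl of compound 1

The source may report more compounds than this note shows. Statements on the series, on what has been measured and on what is new or still open speak of the compounds shown alone.

The series is followed in a functional assay on HepG2 cells (Homo sapiens) for inhibition, read by MTT assay, with a stated time of 48 h; a lower number here means a stronger inhibitor, a higher number a weaker inhibitor. Compound 1 `c1ccc(-c2ccnc3c2c(-c2ccccc2)nn3-c2ccccc2)cc1` gives 3210 nM in this assay, the lower of the two numbers recorded so far. Compound 2 `Cc1ccc(C(=O)C=CNc2cc(-c3ccccc3)nn2-c2ccccc2)cc1`, built on a different core, gives 7320 nM in this assay. Compound 3 `COc1ccc(-c2ccnc3c2c(-c2ccccc2)nn3-c2ccccc2)cc1` is the unmeasured analogue of compound 1; it differs by methoxy in place of hydrogen on an aromatic carbon. Going by the values given here, no measured pair shows what such a change does here, so the step from compound 1 to compound 3 is expected to be small, a 1.1-fold lower number from compound 1 to compound 3 (0.03 log units; within the scatter), likely within the scatter in either direction. On this basis compound 3 is estimated at 3000 nM, with a range from 1200 nM to 8000 nM.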

Compound 3, half-maximal inhibitory concentration: 6590 nM
The estimate for compound 3 lay 2.2-fold (0.34 log units) below the measured number; measured number inside the range.
By their numbers in this assay, from the lowest: compound 1; then compounds 3 and 2 (each within the scatter of the next).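

Methoxy on this ring, para to a large group, is not a silent change: in this assay phenyl to 4-methoxyphenyl gives a 2.1-fold higher number from compound 1 to compound 3 (0.31 log units; beyond the scatter) as a modest loss of inhibition. Going by these compounds alone, this is the first step read at this position, and it shows that the position responds to substitution. Nothing available explains the loss.

As far as these compounds go, whether the loss is specific to methoxy remains open, since a hydroxyl, an amine or a fluorine at this carbon could separate methoxy from substitution in general. From the compounds shown here alone, the effect of methoxy elsewhere on this ring also remains open.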